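Swapping the methoxyphenyl amide for a benzofuran amide

The source may report more compounds than this note shows. Statements on the series, on what has been measured and on what is new or still open speak of the compounds shown alone.

In a functional assay on HT-29 cells (Homo sapiens) for cytotoxicity, read by MTT assay, with a stated time of 72 h (a higher number here means a weaker inhibitor, a lower number a stronger inhibitor), compound 3 `COc1ccc(C(=O)NC[C@H]2c3[nH]c4ccccc4c3C[C@H]3[C@H]4c5[nH]c6ccccc6c5C[C@@H]([C@H](C#N)N23)N4C)cc1` gives 840 nM, the highest number among the three measured compounds, so it is the weakest of them. Compound 1 `CN1[C@@H]2c3[nH]c4ccccc4c3C[C@H]1[C@H](C#N)N1[C@@H](CNC(=O)c3cccc(C(F)(F)F)c3)c3[nH]c4ccccc4c3C[C@@H]21` gives 140 nM and compound 2 `CN1[C@@H]2c3[nH]c4ccccc4c3C[C@H]1[C@H](C#N)N1[C@@H](CNC(=O)c3ccc(Cl)cc3)c3[nH]c4ccccc4c3C[C@@H]21` gives 130 nM. Between these two aryl amides, a 1.1-fold lower number from compound 1 to compound 2 (0.03 log units; within the scatter), whereas a 6.0-fold higher number from compound 1 to compound 3 (0.78 log units; beyond the scatter) and a 6.5-fold higher number from compound 2 to compound 3 (0.81 log units; beyond the scatter). Compound 4 `CN1[C@@H]2c3[nH]c4ccccc4c3C[C@H]1[C@H](C#N)N1[C@@H](CNC(=O)c3cc4ccccc4o3)c3[nH]c4ccccc4c3C[C@@H]21` has not been measured; it differs from compound 3 in that (1-benzofuran-2-yl in place of 4-methoxyphenyl on a carbonyl carbon). Within the data shown here, no measured step involves 1-benzofuran-2-yl, but the two other aryl amides both sit modestly below compound 3, so a gain of similar size is expected, and the expected step is a 3.4-fold lower number from compound 3 to compound 4 (0.53 log units; beyond the scatter). Compound 4 is therefore estimated to give about 250 nM, with a range from 80 nM to 900 nM.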

Compound 4, half-maximal inhibitory concentration: 850 nM
Beside the measured number, compound 4's estimate is 3.4-fold (0.53 log units) below it, within the range that was stated.
By their numbers in this assay, from the lowest: compounds 2 and 1 (each within the scatter of the next); then compounds 3 and 4 (each within the scatter of the next).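

In this assay, 1-benzofuran-2-yl in place of 4-methoxyphenyl on the carbonyl carbon gives a 1.0-fold higher number from compound 3 to compound 4 (0.01 log units; within the scatter), so a group with a fused five-membered ring reads the same here as the methoxy-bearing ring. The gap to the halogen-bearing aryl amides remains, at a 6.5-fold higher number from compound 2 to compound 4 (0.82 log units; beyond the scatter) and a 6.1-fold higher number from compound 1 to compound 4 (0.78 log units; beyond the scatter). Across these four compounds, the two aryl groups containing oxygen group together, apart from the two containing halogen, and no compound goes against this. Nothing measured here explains that split. From the compounds shown here alone, whether an unsubstituted phenyl or an aminophenyl would sit with compound 1 and compound 2 or with compound 3 and compound 4 stays open.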